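A few compounds are considered here, and "the series" means these few. Any claim that something is new, unique, unknown or untested is made for them only; others in the source may bear on it.

Working notes on the series

Three members of this series have been run in a functional assay on KM12 cells (Homo sapiens) for cytotoxicity, read by sulforhodamine B assay, with a stated time of 48 h; on this read-out higher numbers stand for lower toxicity in this test and lower numbers for higher toxicity in this test. Compound 1 `ClCc1ccccc1Cn1cnc2c(Cl)nc(Cl)nc21` gives 5880 nM. Compound 2 `ClCc1ccccc1Cn1cnc2c(Cl)ncnc21` gives 66100 nM. Compound 3 `ClCc1ccccc1Cn1cnc2ncnc(Cl)c21` gives 38000 nM. Compounds 2 and 3 share the same atoms joined differently; the difference between the two cores is not broken down here, and their two values lie within the scatter of each other, so no order between them is claimed. Compound 1 stands apart from both, as its value and that of compound 3 show.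

One structural change is seen twice. Within the measured pairs it runs from compound 2 to compound 1: chloro in place of hydrogen on an aromatic carbon. This gave an 11-fold lower number from compound 2 to compound 1 (1.05 log units; beyond the scatter) in this assay. The same change, word for word in its surroundings, carries compound 3 to compound 4 `ClCc1ccccc1Cn1cnc2nc(Cl)nc(Cl)c21`, not yet measured: chloro in place of hydrogen on an aromatic carbon.

The expectation for compound 4 rests on compound 3 giving 38000 nM and on the earlier step of an 11-fold lower number from compound 2 to compound 1 (1.05 log units; beyond the scatter). Two occurrences are too few to treat the step as fixed, so the estimate allows for a smaller effect as well as a match. The expected step is a 7.6-fold lower number from compound 3 to compound 4 (0.88 log units; beyond the scatter). Compound 4 is estimated to give 5000 nM in this assay, expected to fall between 1500 nM and 20000 nM.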

Compound 4, concentration lethal to 50% of the cells: 56200 nM
Compound 4: the middle estimate sits 11-fold (1.05 log units) below what was measured; measured number above the stated range.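

In this assay the new step is a 1.5-fold higher number from compound 3 to compound 4 (0.17 log units; within the scatter), so compound 3 and compound 4 cannot be told apart, whereas the same chloro in place of hydrogen gave a clear step on the core of compound 2. The change therefore does not carry over from one core to the other in this series, and the two steps differ: the same change on two cores in this assay, an 11-fold lower number (1.05 log units; beyond the scatter) from compound 2 to compound 1 and a 1.5-fold higher number (0.17 log units; within the scatter) from compound 3 to compound 4, 17-fold (1.22 log units) apart, beyond the scatter of two such steps. Among these compounds, this shows that a step read on the core of compound 2 cannot be applied directly to the core of compound 3, but with only one pair on each core it does not show why the two cores part or how the change would behave on a further core.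

The compounds shown leave open whether another group on the aromatic carbon between two ring nitrogen atoms, such as an amine or a methoxy group, would also differ between the two cores. From the compounds shown here alone, all four compounds also carry the same chloromethyl group, so it remains open how either core would respond if that group gave way to a longer chain or a carboxylic acid.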